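The source may hold more compounds than are shown below. What is called first, only, known or untested is meant among the compounds shown, and "the series" means these compounds.

Measured in an ADME assay on HeLa cells (Homo sapiens) for cytotoxicity, read by MTT assay, with a stated time of 72 h; on this read-out lower numbers stand for stronger inhibition of growth and higher numbers for weaker inhibition of growth:

compound 1 `O=C(/C=C\c1ccccc1O)N1N=C(c2ccncc2)OC1c1c[nH]c2ccccc12` gives 26.8 ug/mL.
compound 2 `Cc1ccc(/C=C\C(=O)N2N=C(c3ccncc3)OC2c2c[nH]c3ccccc23)cc1` gives > 30 ug/mL, a limit of the assay.
compound 3 `COc1ccc(/C=C\C(=O)N2N=C(c3ccncc3)OC2c2c[nH]c3ccccc23)cc1` gives > 30 ug/mL, a limit of the assay.

Going by the values given here, compound 1 is the only member of the series with a number; the other two values are limits. Compound 4 `O=C(/C=C\c1ccc(F)cc1)N1N=C(c2ccncc2)OC1c1c[nH]c2ccccc12` is not yet measured. It differs from compound 1 in one place: 4-fluorophenyl in place of 2-hydroxyphenyl on a double-bonded chain carbon bound to a double-bonded chain carbon.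

Two measured steps leave the same 2-hydroxyphenyl from the same place: an at least 1.1-fold higher number from compound 1 to compound 2 (0.04 log units; that floor lies within the scatter) and an at least 1.1-fold higher number from compound 1 to compound 3 (0.04 log units; that floor lies within the scatter). Among the compounds with values here, both are floors only, and the floors lie within the scatter, so they show only that the number did not fall. The step that the two limits leave unreadable from compound 2 to compound 3 gives no further size. What the two steps share is the limit of > 30 ug/mL in this assay, at which 2 of the 3 values shown sit, which is where both replacements ended.

For compound 4 the expectation is therefore a number no lower than that of compound 1, with a real chance that the assay again reports only a limit. The estimated step of a 1.3-fold higher number from compound 1 to compound 4 (0.10 log units; within the scatter) is taken as a modest rise. Compound 4 is expected at 34 ug/mL, with a range from 17 ug/mL to 70 ug/mL.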

Compound 4, concentration for 50% growth inhibition: > 30 ug/mL
Compound 4: only a limit was reported; the forecaster's own chance of this, stated with the estimate: 55%; the middle value does not contradict the limit.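

In this assay, going by these compounds alone, the change to 4-fluorophenyl in place of 2-hydroxyphenyl on a double-bonded chain carbon gives an at least 1.1-fold higher number from compound 1 to compound 4 (0.04 log units; that floor lies within the scatter) and so shows only that the number did not fall. Compound 4 gives > 30 ug/mL as a limit of the assay and not a number, and the steps that link compound 2 and compound 3 to compound 4 cannot be read. Within the data shown here, at this place a third replacement, now carrying fluoro, ends where 4-methylphenyl and 4-methoxyphenyl ended, which leaves 2-hydroxyphenyl in compound 1 as the only group here with a number and widens the share of the series at the ceiling: the limit of > 30 ug/mL in this assay, at which 3 of the 4 values shown sit.

Open, from the compounds shown here alone, is whether 4-hydroxyphenyl or 2-fluorophenyl at this place would give a number rather than a limit, which would separate the hydroxy group itself from where it sits on the ring. Equally open, going by these compounds, is what an amine or a carboxylic acid on this phenyl ring would do in this assay and whether any such group would give a number clearly lower than that of compound 1.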